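Two Methyls for a Methoxy on the Hydrazone Aryl

The source may hold more compounds than are shown below. What is called first, only, known or untested is meant among the compounds shown, and "the series" means these compounds.

Three compounds on a shared core have been measured in a functional assay on HT-29 cells (Homo sapiens) for cytotoxicity, read by MTT assay, with a stated time of 72 h; a higher number here means a weaker inhibitor, a lower number a stronger inhibitor:

Compound 1, `CN(C)CCn1cnnc1-c1cc(Oc2ccc(NC(=O)N/N=C/c3c[nH]c4ccccc34)cc2F)ccn1`: 1300 nM
Compound 2, `CN(C)CCn1cnnc1-c1cc(Oc2ccc(NC(=O)N/N=C/c3ccccc3O[N+](=O)[O-])cc2F)ccn1`: 950 nM
Compound 3, `COc1cc(/C=N/NC(=O)Nc2ccc(Oc3ccnc(-c4nncn4CCN(C)C)c3)c(F)c2)ccc1O`: 120 nM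

Compound 3 stands lowest of the three numbers. The steps to it are both beyond the scatter: an 11-fold lower number from compound 1 to compound 3 (1.03 log units; beyond the scatter) and a 7.9-fold lower number from compound 2 to compound 3 (0.90 log units; beyond the scatter). The remaining step, a 1.4-fold lower number from compound 1 to compound 2 (0.14 log units; within the scatter), lies within the scatter.

Compound 4, `Cc1cc(/C=N/NC(=O)Nc2ccc(Oc3ccnc(-c4nncn4CCN(C)C)c3)c(F)c2)cc(C)c1O`, differs from compound 3 by 4-hydroxy-3,5-dimethylphenyl in place of 4-hydroxy-3-methoxyphenyl on a carbon with a double bond to nitrogen. The measured steps that bear on this change are the three exchanges of the aryl group on the same carbon, which ran from within the scatter to large. Both large steps, however, lead into compound 3 and none starts from it, so they set the range of what an aryl exchange can do without pointing to a direction for this particular one. A step of modest size is therefore expected for compound 4, a 1.8-fold higher number from compound 3 to compound 4 (0.26 log units; within the scatter), most likely toward a somewhat higher number but possibly within the scatter. Compound 4 is estimated at 220 nM, expected to fall between 70 nM and 700 nM.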

Compound 4, half-maximal inhibitory concentration: 1220 nM
For compound 4 the middle estimate is 5.5-fold (0.74 log units) below the measured one; the whole stated range lies below it.
By their numbers in this assay, from the lowest: compound 3; then compounds 2, 4 and 1 (each within the scatter of the next).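

In this assay, 4-hydroxy-3,5-dimethylphenyl in place of 4-hydroxy-3-methoxyphenyl on the carbon with a double bond to nitrogen gives a 10-fold higher number from compound 3 to compound 4 (1.01 log units; beyond the scatter), a large step although the number of heavy atoms stays the same and the entering group differs by a carbon for an oxygen. The other two steps, a 1.3-fold higher number from compound 2 to compound 4 (0.11 log units; within the scatter) and a 1.1-fold lower number from compound 1 to compound 4 (0.03 log units; within the scatter), place compound 4 within the scatter of both, so that among these four aryl groups compound 3 alone stands apart. Nothing at hand explains the step.

Going by these compounds, whether the large step depends on the methoxy itself remains open. An ethoxy group or an amine in place of the methoxy of compound 3 would test how narrowly this position tolerates change.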